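Ring closure of the side chain on the shared core

This account rests on a few compounds, and the source may have more. Where it says the series, first, only, none or still open, it means among the compounds named here.

compound 1 `C/C(=C\Cc1c(O)ccc2c1O[C@H](c1ccc(O)cc1)CC2=O)C/C=C/C(C)(C)O` — in a functional assay on HepG2 cells (Homo sapiens) for cytotoxicity, read by MTT assay (on this read-out higher numbers stand for weaker inhibition and lower numbers for stronger inhibition), compound 1 gives > 10000 nM, a limit
compound 2 `C=C(C)C(O)CC/C(C)=C/Cc1c(O)ccc2c1O[C@H](c1ccc(O)cc1)CC2=O` — in this assay compound 2 gives > 10000 nM, a limit
compound 3 `C=C(CCC=C(C)C)C(O)Cc1c(O)ccc2c1O[C@H](c1ccc(O)cc1)CC2=O` — in this assay compound 3 gives > 10000 nM, a limit

Each of these values is a limit of the assay and not a number. Compound 3 therefore stands at the limit of > 10000 nM in this assay, at which 3 of the 3 values shown sit, with no number of its own. Among the measured compounds shown here, none of the measured steps can be read: a step that the two limits leave unreadable from compound 1 to compound 3, a step that the two limits leave unreadable from compound 2 to compound 3 and a step that the two limits leave unreadable from compound 1 to compound 2 are all hidden by the limits on both sides, so the series gives no readable size for any exchange of the side chain so far.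

Compound 4 `CC1=CCC(O)C(C)(C)C1Cc1c(O)ccc2c1O[C@H](c1ccc(O)cc1)CC2=O` is yet to be measured in this assay. It differs from compound 3 by a group of 10 heavy atoms (9 carbon, 1 oxygen; one six-membered non-aromatic ring of carbon only) in place of a group of 10 heavy atoms (9 carbon, 1 oxygen; no ring), on a saturated chain carbon bound to an aromatic carbon. For the measured compounds named here, the steps that bear on this change, from compound 1 and compound 2 to compound 3, rest only on limits and give no size. Nothing measured here supports a step beyond the scatter in either direction, so the expectation is that compound 4 also sits at the limit. The estimate for compound 4 in this assay is 15000 nM, with a range from 6000 nM to 40000 nM. This estimate means a step that the limit leaves unreadable from compound 3 to compound 4 is expected, which is not expected to be readable against the limit.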

Compound 4, half-maximal inhibitory concentration: > 10000 nM
Compound 4: only a limit was reported; the forecaster's own chance of this, stated with the estimate: 80%; the middle value does not contradict the limit.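

In this assay compound 4 gives > 10000 nM, which is a limit. No step from compound 1, compound 2 or compound 3 to compound 4 can be read: the limit of > 10000 nM in this assay, at which 4 of the 4 values shown sit.

The compounds shown leave open whether the ring-bearing side chain of compound 4 differs at all in this assay from the open chains of compound 1, compound 2 and compound 3.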